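The source may hold more compounds than are shown below. What is called first, only, known or untested is meant among the compounds shown, and "the series" means these compounds.

Compound 2 `CCC1(CCCCN2CCN(c3ccc(OC)cc3)CC2)C(=O)Nc2ccccc21` shares its core with compound 1 `CCC1(CCCCN2CCN(c3ccc(C)c(Cl)c3)CC2)C(=O)Nc2ccccc21` and compound 3 `CCC1(CCCCN2CC=C(c3ccc(F)cc3)CC2)C(=O)Nc2ccccc21`. In a functional assay on the whole organism (strain Wistar) with Rattus norvegicus as the target, with a stated time of 5 min (a lower number here means that less compound is needed, a higher number that more compound is needed for the effect), compound 2 gives > 20 mg/kg, which is a limit of the assay and not a number. Compound 1 gives > 20 mg/kg, likewise only a limit. Compound 3 gives 20 mg/kg. The step that the two limits leave unreadable from compound 1 to compound 2 cannot be read, because both of its ends sit at the limit of > 20 mg/kg in this assay, at which 2 of the 3 values shown sit. Compound 4 `CCC1(CCCCN2CCN(c3cccc(OC)c3)CC2)C(=O)Nc2ccccc21` differs from compound 2 by 3-methoxyphenyl in place of 4-methoxyphenyl on an amine nitrogen in a ring. Going by the values given here, no measured pair moves a methoxy group around its ring, so no measured step bears directly on this change, and the single measured step is itself unreadable. Compound 2 therefore stands at a limit with nothing around it to point up or down, and no move beyond the scatter is expected in either direction. Compound 4 is expected to give about 20 mg/kg in this assay, with a range from 10 mg/kg to 40 mg/kg. The step of a number no higher from compound 2 to compound 4 (the limit leaves the size open) that this estimate means is expected to stay within the scatter of repeated measurements, and a further limit rather than a number is considered the more likely outcome.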

Compound 4, minimum effective dose: > 20 mg/kg
Compound 4: a limit, no number; the forecaster's own chance of this, stated with the estimate: 60%; the middle value sits exactly at the limit.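

Compound 4 sits at a limit of the assay, as do compound 1 and compound 2, so neither new step to compound 4 can be read: the limit of > 20 mg/kg in this assay, at which 3 of the 4 values shown sit.

As far as these compounds go, whether 3-methoxyphenyl, 4-methoxyphenyl and 3-chloro-4-methylphenyl differ at all on the shared core remains open.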